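A few compounds are considered here, and "the series" means these few. Any claim that something is new, unique, unknown or untested is made for them only; others in the source may bear on it.

Measured so far in an assay on C3H 10T1/2 cells for inhibition of Sonic hedgehog protein (Mus musculus), read by a luciferase reporter; a lower number here means a stronger inhibitor, a higher number a weaker inhibitor:

Compound 1, `O=C(Nc1ccc(Cl)c(-c2ccccn2)c1)c1cccc(Cl)c1`: 1500 nM
Compound 2, `O=C(Nc1ccc(Cl)c(-c2ccccn2)c1)c1ccc(Cl)cc1`: 1500 nM
Compound 3, `CS(=O)(=O)c1cccc(C(=O)Nc2ccc(Cl)c(-c3ccccn3)c2)c1`: 120 nM

Compounds 1 and 2 share one core and differ only in the acyl part: 4-chlorophenyl in place of 3-chlorophenyl on a carbonyl carbon. Between them no change at the digits printed from compound 1 to compound 2 (within the scatter). Compound 3 carries methylsulfonyl in place of chloro on an aromatic carbon, and a 13-fold lower number from compound 1 to compound 3 (1.10 log units; beyond the scatter).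

Compound 4, `CS(=O)(=O)c1ccc(C(=O)Nc2ccc(Cl)c(-c3ccccn3)c2)cc1`, is the same kind of change made on compound 2: methylsulfonyl in place of chloro on an aromatic carbon. The two differ in where the group sits on the ring, meta to a large group in compound 3 against para to a large group in compound 4, so the earlier step is a guide, not a repeat.

Compound 4 is expected to give 200 nM in this assay, with a range of 60 nM to 700 nM.

The step from compound 2 to compound 4 is estimated as a 7.5-fold lower number from compound 2 to compound 4 (0.88 log units; beyond the scatter), smaller than the measured one because a 13-fold lower number from compound 1 to compound 3 (1.10 log units; beyond the scatter) was obtained at a different place on the ring.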

Compound 4, half-maximal inhibitory concentration: 40 nM
For compound 4 the middle estimate is 5.0-fold (0.70 log units) above the measured one; the measured number lies below the stated range.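

In this assay, methylsulfonyl in place of chloro on an aromatic carbon gives a 38-fold lower number from compound 2 to compound 4 (1.57 log units; beyond the scatter). The number falls on both cores, but the size of the step does not carry over from one core to the other: the same change on two cores in this assay, a 13-fold lower number (1.10 log units; beyond the scatter) from compound 1 to compound 3 and a 38-fold lower number (1.57 log units; beyond the scatter) from compound 2 to compound 4, 3.0-fold (0.48 log units) apart, beyond the scatter of two such steps Two pairs give no rule for any other core, and they do not show what sets the size of the step.

Still open, on these data alone, is whether an amine, a nitrile or a carboxylic acid, placed para to a large group on the core of compound 4, would lower the number as methylsulfonyl does. Also open, as far as these compounds go, is how a longer chain on the sulfur, such as ethylsulfonyl, would read at that place.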